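Replacing the Acid by a tert-Butyl Amide: Expected Cytotoxicity

This account rests on a few compounds, and the source may have more. Where it says the series, first, only, none or still open, it means among the compounds named here.

Compound 1, `C=CC1=C(C(=O)Nc2ccccc2OC)C(c2ccc(F)cc2)OC1`: in a functional assay on SW480 cells (Homo sapiens) for cytotoxicity, read by MTT assay, with a stated time of 24 h (a higher number here means a weaker inhibitor, a lower number a stronger inhibitor), compound 1 gives > 100000 nM, which is a limit of the assay.
Compound 2, `C=CC1=C(C(=O)Nc2cccc(C)c2)C(c2ccc(F)cc2)OC1`: in this assay compound 2 gives > 100000 nM, again a limit.
Compound 3, `C=CC1=C(C(=O)O)C(c2ccc(F)cc2)OC1`: in this assay compound 3 gives > 100000 nM, also a limit.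

Compound 3 thus stands only at a limit, and every value shown sits there (the limit of > 100000 nM in this assay, at which 3 of the 3 values shown sit), so the steps a step that the two limits leave unreadable from compound 1 to compound 2 and a step that the two limits leave unreadable from compound 2 to compound 3 cannot be read. Compound 4, `C=CC1=C(C(=O)NC(C)(C)C)C(c2ccc(F)cc2)OC1`, differs from compound 3 by (tert-butyl)amino in place of hydroxy on a carbonyl carbon. For the measured compounds named here, no measured step bears readably on this change, since all rest on (the limit of > 100000 nM in this assay, at which 3 of the 3 values shown sit). The expected step that the limit leaves unreadable from compound 3 to compound 4 is therefore taken as no readable movement. Compound 4 is estimated at 200000 nM, expected between 60000 nM and 600000 nM, most likely reported only as a limit.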

Compound 4, half-maximal inhibitory concentration: > 100000 nM
Compound 4: a limit, no number; the forecaster's own chance of this, stated with the estimate: 85%; the middle value does not contradict the limit.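

Compound 4 sits at the same limit as compound 1, compound 2 and compound 3, so no step among these compounds can be read: the limit of > 100000 nM in this assay, at which 4 of the 4 values shown sit.

The compounds shown leave open which change on the carbonyl carbon, if any, would give a true number rather than a limit in this assay.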